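The compounds below may be only part of what the source reports. "The series", "measured", "known", "first", "only" and "open" are said of these compounds alone.

Compound 3, whose structure is `Cc1ccc(S(=O)(=O)n2cc(-c3cc(C(F)(F)F)cc(-c4cn(S(=O)(=O)c5ccc(C)cc5)c5cc(Br)ccc45)n3)c3ccc(Br)cc32)cc1`, is measured in a functional assay on P388 cells (Mus musculus) for inhibition, tested at 0.1 uM; a higher number here means a stronger effect of the compound at the concentration tested, a lower number a weaker effect. There compound 3 gives 8.1%, the second highest of the three numbers. For comparison, compound 2 (`COc1ccc2c(c1)c(-c1cc(C(F)(F)F)cc(-c3cn(S(=O)(=O)c4ccc(C)cc4)c4ccc(OC)cc34)n1)cn2S(=O)(=O)c1ccc(C)cc1`) gives 9.3%, and compound 1 (`COc1ccc2c(c1)c(-c1cc(C(F)(F)F)c(C#N)c(-c3cn(S(=O)(=O)c4ccc(C)cc4)c4ccc(OC)cc34)n1)cn2S(=O)(=O)c1ccc(C)cc1`) gives 1.7%; both of these lie within the scatter of the value of compound 3, so no order among the three can be read from them.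

Compound 4, with the structure `Cc1ccc(S(=O)(=O)n2cc(-c3cc(C(F)(F)F)c(C#N)c(-c4cn(S(=O)(=O)c5ccc(C)cc5)c5cc(Br)ccc45)n3)c3ccc(Br)cc32)cc1`, has not yet been measured in this assay. It differs from compound 3 in one place: cyano in place of hydrogen on an aromatic carbon

For the measured compounds named here, one measured step bears on this change, and it runs the other way. The step of a number 7.6 percentage points higher from compound 1 to compound 2 (within the scatter) removed a cyano group at the same kind of position and gave a small rise, within the scatter. The move from compound 3 to compound 4 puts a cyano group back in, so a small drop, also within the scatter, is the natural expectation, amounting to a step of about a number 6.6 percentage points lower from compound 3 to compound 4 (within the scatter). Compound 4 is therefore expected to give roughly 1.5% in this assay, with a plausible range from -6% to 11%.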

Compound 4, a percentage reported as inhibition, at one concentration (the size of the read-out at that concentration, not a potency): 3.1%
For compound 4 the middle estimate is 1.6 percentage points below the measured one, and the stated range covers the measured number.
By their numbers in this assay, from the lowest: compounds 1, 4, 3 and 2 (each within the scatter of the next).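

Until now, the exchange of hydrogen for cyano at this place, ortho to a trifluoromethyl group and two atoms from the ring nitrogen, had been read on one core only; in this assay it now has a second reading, a number 5 percentage points lower from compound 3 to compound 4 (within the scatter). The two readings agree on both cores: the same change on two cores in this assay, a number 7.6 percentage points higher (within the scatter) from compound 1 to compound 2 and a number 5 percentage points higher (within the scatter) from compound 4 to compound 3, 2.6 percentage points apart, within the scatter of two such steps Neither step lies beyond the scatter, so the two pairs show no effect of the cyano group, only that no large effect appears on either core at the concentration tested.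

As far as these compounds go, it remains open whether another group on this carbon, such as an amine or a carboxylic acid, would move the read-out beyond the scatter. All these numbers come from a single concentration, so they show only the size of the effect at that concentration.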